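Swapping the Thiophene on a Ubiquitin Hydrolase Inhibitor

The source may report more compounds than this note shows. Statements on the series, on what has been measured and on what is new or still open speak of the compounds shown alone.

Compound 1 `Cn1nc2c(=O)n(CC3(O)CCN(Cc4ccc(-c5ccco5)cc4Cl)CC3)cnc2c1-c1ccc(CO)cc1`: 42.5 nM
Compound 2 `Cn1nc2c(=O)n(CC3(O)CCN(Cc4ccc(-c5ccco5)cc4Cl)CC3)cnc2c1-c1ccc(C2(N)CC2)cc1`: 66.1 nM
Compound 3 `Cc1ccc(-c2ccc(CN3CCC(O)(Cn4cnc5c(-c6ccc(CN)cc6)n(C)nc5c4=O)CC3)c(Cl)c2)s1`: 101 nM

All three were tested in an assay on isolated protein for inhibition of ubiquitin carboxyl-terminal hydrolase 7 (Homo sapiens), with stated times of 30 min and 2 h; on this read-out higher numbers stand for weaker inhibition and lower numbers for stronger inhibition. Compound 3 gives the highest of the three numbers; its gap to compound 1 lies beyond the scatter, while its gap to compound 2 lies within it. For the measured compounds named here, the only step between compounds differing in one place is a 1.6-fold higher number from compound 1 to compound 2 (0.19 log units; within the scatter), and it alters a group on the other aromatic ring, so it says nothing about the thiophene. Compound 4 `Cn1nc2c(=O)n(CC3(O)CCN(Cc4ccc(-c5ccsc5)cc4Cl)CC3)cnc2c1-c1ccc(CN)cc1` differs from compound 3 in one place: thiophen-3-yl in place of 5-methylthiophen-2-yl on an aromatic carbon. Going by the values given here, no measured step touches this part of the molecule, so the expected step for compound 4 is a 1.0-fold lower number from compound 3 to compound 4 (0.00 log units; within the scatter), none beyond the scatter. Compound 4 is therefore estimated at 100 nM, with a range from 40 nM to 250 nM.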

Compound 4, half-maximal inhibitory concentration: 59.5 nM
The estimate for compound 4 lay 1.7-fold (0.23 log units) above the measured number, and the stated range covers the measured number.
By their numbers in this assay, from the lowest: compounds 1, 4, 2 and 3 (each within the scatter of the next, the first and the last beyond it).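

In this assay, the swap gives a 1.7-fold lower number from compound 3 to compound 4 (0.23 log units; within the scatter), so this place on the chlorinated ring accepts thiophen-3-yl as well as 5-methylthiophen-2-yl, with no difference beyond the scatter. The swap removes the methyl and alters how the thiophene is attached, and this single step cannot separate the two. Nothing available bears on the reason for this result. Thiophen-2-yl without the methyl would separate those two changes. Going by these compounds, whether a group of a different kind, such as a carboxylic acid or an amine, would give a similar number here remains open.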